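Cyclobutyl in Place of sec-Butyl on the Shared Core

The source may hold more compounds than are shown below. What is called first, only, known or untested is meant among the compounds shown, and "the series" means these compounds.

Compound 1 `CCC(C)COc1cccc2ccc(N)nc12`: 36 nM
Compound 2 `Nc1ccc2cccc(OCC3CC4CCC3C4)c2n1`: 137 nM
Compound 3 `CC(C)(C)CCOc1cccc2ccc(N)nc12`: 201 nM

These three compounds share one core and differ only in the group sitting on a saturated chain carbon bound to an oxygen on an aromatic ring. In an assay on cells with melanin-concentrating hormone receptor 1 (Homo sapiens) as the target, read by radioligand binding (a higher number here means a weaker inhibitor, a lower number a stronger inhibitor), compound 1 holds the lowest number of the three; compound 2 is nearest and compound 3 furthest, both beyond the scatter. Compound 4 `Nc1ccc2cccc(OCC3CCC3)c2n1` is not yet measured and differs from compound 1 in one place: cyclobutyl in place of sec-butyl on a saturated chain carbon bound to an oxygen on an aromatic ring. Within the data shown here, the one measured step that bears on this change is a 5.6-fold higher number from compound 1 to compound 3 (0.75 log units; beyond the scatter), where a different group at the same place raised the number. Compound 2, which also carries a ring at that place, likewise shows a higher number than compound 1. Compound 4 is therefore expected to give a modestly higher number, a 2.4-fold higher number from compound 1 to compound 4 (0.37 log units; beyond the scatter). The estimate for compound 4 is 85 nM, with a range from 30 nM to 250 nM.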

Compound 4, half-maximal inhibitory concentration: 432 nM
Estimate against measurement, compound 4: 5.1-fold (0.71 log units) below; the whole stated range lies below it.
By their numbers in this assay, from the lowest: compound 1; then compounds 2 and 3 (each within the scatter of the next); then compound 4.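

Cyclobutyl in place of sec-butyl gives a 12-fold higher number from compound 1 to compound 4 (1.08 log units; beyond the scatter) even though both groups hold four carbons, so this position separates two groups of the same carbon count. Cyclobutyl in place of neopentyl also raises the number, with a 2.1-fold higher number from compound 3 to compound 4 (0.33 log units; beyond the scatter) on top of the rise already seen with neopentyl. No measurement shown gives a reason for either step. The compounds shown leave open how a cyclopropyl or cyclopentyl group would fare at this place, and whether an amine on the chain would bring the number back towards that of compound 1.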